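This account rests on a few compounds, and the source may have more. Where it says the series, first, only, none or still open, it means among the compounds named here.

Compound 1 `Cc1ccccc1NNC(=O)CCC(C)C` in an in vitro functional assay on 1321-N1 cells for antagonist activity at P2X purinoceptor 7 (Rattus norvegicus), read by FLIPR and calcium flux; on this read-out higher numbers stand for weaker inhibition and lower numbers for stronger inhibition: 339 nM
Compound 2 `Cc1ccccc1NNC(=O)C1CCCCC1` in this assay: 245 nM
Compound 3 `COc1ccc(C2(C(=O)NNc3cccc4ncccc34)CCCCC2)cc1` in this assay: 51.3 nM

Compound 3 has the lowest number of the three, and its gaps to compound 2 and to compound 1 both lie beyond the usual scatter, so it is the strongest inhibitor among the measured compounds. Compound 4 `O=C(NNc1cccc2ncccc12)C1(c2cccc(F)c2)CCCCC1` has not yet been measured. It differs from compound 3 in one place: 3-fluorophenyl in place of 4-methoxyphenyl on a saturated ring carbon. For the measured compounds named here, no pair of measured compounds shows this particular change, so there is no measured step to lean on, and the shared core of compound 3 is kept. The step from compound 3 to compound 4 is expected to be a 1.4-fold higher number from compound 3 to compound 4 (0.13 log units; within the scatter), small and within the usual scatter. Compound 4 is therefore estimated at 70 nM, with a range from 25 nM to 200 nM.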

Compound 4, half-maximal inhibitory concentration: 257 nM
Compound 4: the middle estimate sits 3.7-fold (0.56 log units) below what was measured; the whole stated range lies below it.
By their numbers in this assay, from the lowest: compound 3; then compounds 2, 4 and 1 (each within the scatter of the next).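

At this saturated ring carbon the choice of aryl group matters: in this assay, 3-fluorophenyl in place of 4-methoxyphenyl gives a 5.0-fold higher number from compound 3 to compound 4 (0.70 log units; beyond the scatter), a step beyond the scatter. Of these two groups, 4-methoxyphenyl goes with the stronger inhibition. Nothing at hand explains this difference.

This single change alters both the substituent and where it sits on the phenyl ring, so the two effects cannot be separated. A 4-fluorophenyl, 3-methoxyphenyl or unsubstituted phenyl group at this place would be needed to tell them apart.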